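The source may hold more compounds than are shown below. What is called first, only, known or untested is meant among the compounds shown, and "the series" means these compounds.

Compound 1, `Cc1cc(-c2ccccc2)c(S(C)(=O)=O)cc1C(=O)N=C(N)N`, in a functional assay for inhibition of sodium/hydrogen exchanger (Oryctolagus cuniculus) (a higher number here means a weaker inhibitor, a lower number a stronger inhibitor), gives 19 nM. Compound 2, `Cc1cc(Sc2ccncc2)c(S(C)(=O)=O)cc1C(=O)N=C(N)N`, in this assay gives 13 nM.

Going by the values given here, compound 2 has the lower of these two numbers, but its only neighbour is compound 1, and the step of a 1.5-fold lower number from compound 1 to compound 2 (0.16 log units; within the scatter) lies within the scatter, so the two cannot be ranked. Compound 3, `Cc1cc(O)c(S(C)(=O)=O)cc1C(=O)N=C(N)N`, has not yet been measured. The change from compound 2 to compound 3 is hydroxy in place of (pyridin-4-yl)sulfanyl on an aromatic carbon. Among the compounds with values here, the one measured step bears on this only loosely: it swapped one six-membered aromatic ring group for another and stayed within the scatter. Within the data shown here, removing the ring group entirely in favour of hydroxy is a change of a different kind, for which no measured pair gives guidance, so the number for compound 3 is expected to shift beyond the scatter, toward a weaker inhibitor, with wide uncertainty. Compound 3 is estimated at 60 nM, between 15 nM and 300 nM, a step of a 4.6-fold higher number from compound 2 to compound 3 (0.66 log units; beyond the scatter).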

Compound 3, half-maximal inhibitory concentration: 220 nM
Compound 3: the middle estimate sits 3.7-fold (0.56 log units) below what was measured; low and high end bracket the measured number.
By their numbers in this assay, from the lowest: compounds 2 and 1 (each within the scatter of the next); then compound 3.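

The position is not indifferent to what it carries: exchanging one ring group for another left the number within the scatter, but in this assay hydroxy in place of (pyridin-4-yl)sulfanyl gives a 17-fold higher number from compound 2 to compound 3 (1.23 log units; beyond the scatter). Hydroxy in place of phenyl points the same way, with a 12-fold higher number from compound 1 to compound 3 (1.06 log units; beyond the scatter), so both ring-bearing groups, one joined through sulfur and one joined directly, give stronger inhibitors than hydroxy on this aromatic carbon, ortho to the methylsulfonyl group. No measurement available here explains why the number rises with this change.

Three compounds cannot show whether an aromatic ring is what matters, or whether any group bigger than hydroxy would serve as well. A methoxy group, an amine, or a saturated ring such as piperidine at the same place would help separate these possibilities.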